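Benzyl for oxan-4-yl on an amide-type nitrogen

A few compounds are considered here, and "the series" means these few. Any claim that something is new, unique, unknown or untested is made for them only; others in the source may bear on it.

In a functional assay on the whole organism with Rattus norvegicus as the target (a higher number here means that more compound is needed for the effect, a lower number that less compound is needed), compound 1 `CSc1cc(C)nc(SC)c1NC(=O)N(Cc1ccc(Oc2ccc(F)cc2)cc1)C1CCCCC1` gives < 0.01 mg/kg, which is a limit and not a number. Compound 2 `CSc1cc(C)nc(SC)c1NC(=O)N(Cc1ccc(Oc2ccc(F)cc2)cc1)C1CCOCC1` gives < 0.1 mg/kg, which is likewise only a limit. Compound 3 `CSc1cc(C)nc(SC)c1NC(=O)N(Cc1ccccc1)Cc1ccc(Oc2ccc(F)cc2)cc1` carries benzyl in place of oxan-4-yl on an amide-type nitrogen. Among the measured compounds shown here, the only measured change at this place is a step that the two limits leave unreadable from compound 1 to compound 2, so it offers no size to carry over. The expected step in this assay is therefore modest and uncertain in direction, estimated as a step that the limit leaves unreadable from compound 2 to compound 3. For compound 3 the expected dose is 0.05 mg/kg, with an estimated range from 0.01 mg/kg to 0.3 mg/kg.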

Compound 3, dose for half-maximal effect: < 0.01 mg/kg
Compound 3: a limit, no number; the forecaster's own chance of this, stated with the estimate: 40%; middle value at least 5.0-fold (0.69 log units) away from the limit.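

In this assay, among the compounds shown here, compound 1, compound 2 and compound 3 all give limits and not numbers, so no step among them can be read. From the compounds shown here alone, whether benzyl, oxan-4-yl and cyclohexyl on the amide-type nitrogen differ in dose stays open.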